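A few compounds are considered here, and "the series" means these few. Any claim that something is new, unique, unknown or untested is made for them only; others in the source may bear on it.

This account follows a single change on the amide side of a shared core. Compound 1 `CCn1c(C(=O)N[C@@H](C)C(=O)OC)ccc1C(CC)(CC)c1ccc(OCS(=O)(=O)c2ccccc2)c(C)c1` carries a 1-(methoxycarbonyl)ethyl group on its amide nitrogen. In a functional assay on PC-3 cells (Homo sapiens) for antiproliferative activity, read by MTT assay, with a stated time of 24 h (on this read-out higher numbers stand for weaker inhibition and lower numbers for stronger inhibition), compound 1 gives only a limit, > 50000 nM, and no number (the limit of > 50000 nM in this assay, at which 1 of the 3 values shown sits). Compound 2 `CCn1c(C(=O)NCCO)ccc1C(CC)(CC)c1ccc(OCS(=O)(=O)c2ccccc2)c(C)c1` gives 17700 nM in this assay, and compound 3 `CCn1c(C(=O)N[C@H](C)CO)ccc1C(CC)(CC)c1ccc(OCS(=O)(=O)c2ccccc2)c(C)c1` gives 7790 nM. Both measured steps leading away from compound 1 run the same way: an at least 2.8-fold lower number from compound 1 to compound 2 (0.45 log units; beyond the scatter) and an at least 6.4-fold lower number from compound 1 to compound 3 (0.80 log units; beyond the scatter). Between the two hydroxyl-bearing amides there is a further a 2.3-fold lower number from compound 2 to compound 3 (0.36 log units; beyond the scatter).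

Compound 4 `CCn1c(C(=O)N[C@H](CO)CCO)ccc1C(CC)(CC)c1ccc(OCS(=O)(=O)c2ccccc2)c(C)c1` has not yet been measured. It differs from compound 1 by 3-hydroxy-1-(hydroxymethyl)propyl in place of 1-(methoxycarbonyl)ethyl on an amide-type nitrogen. The entering 3-hydroxy-1-(hydroxymethyl)propyl chain, like the chains of compounds 2 and 3, carries hydroxyl groups rather than an ester, and both of those exchanges lowered the number beyond the scatter, so the same direction is expected here. Compound 4 is therefore expected to show a step of an at least 6.2-fold lower number from compound 1 to compound 4 (0.79 log units; beyond the scatter) in this assay. The estimated value for compound 4 is 8000 nM, with a range from 3000 nM to 25000 nM, placed closer to compound 3 than to compound 2.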

Compound 4, half-maximal inhibitory concentration: 12100 nM
The estimate for compound 4 lay 1.5-fold (0.18 log units) below the measured number, within the range that was stated.
By their numbers in this assay, from the lowest: compounds 3, 4 and 2 (each within the scatter of the next, the first and the last beyond it). At a limit, above all of these: compound 1.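

In this assay, the exchange away from the ester holds for a third hydroxyl-bearing chain, with an at least 4.1-fold lower number from compound 1 to compound 4 (0.61 log units; beyond the scatter); here the 1-(methoxycarbonyl)ethyl and 3-hydroxy-1-(hydroxymethyl)propyl groups match in heavy-atom count, carbon and oxygen alike, but only the entering chain carries hydrogen-bond donors. On this amide-type nitrogen, the further hydroxyl-bearing branch gives no readable separation from the simpler chains: the comparisons show a 1.6-fold higher number from compound 3 to compound 4 (0.19 log units; within the scatter) and a 1.5-fold lower number from compound 2 to compound 4 (0.17 log units; within the scatter), so compound 4 cannot be told apart from either compound 2 or compound 3, although those two are separated from each other. The step from the ester therefore has a lower bound only, as compound 1 stands at a limit and has no number: the limit of > 50000 nM in this assay, at which 1 of the 4 values shown sits.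

The compounds shown leave open whether an amine or a carboxylic acid at the end of the chain on this nitrogen, or a longer chain bearing a hydroxyl group, would match the hydroxyl-bearing chains here. They also leave open how the opposite configuration at the defined stereocentre of the 3-hydroxy-1-(hydroxymethyl)propyl group would read in this assay.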